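A few compounds are considered here, and "the series" means these few. Any claim that something is new, unique, unknown or untested is made for them only; others in the source may bear on it.

Compound 1, `O=C(Nc1cccc(-n2cc(-c3ccncc3)c(-c3ccc(Cl)c(O)c3)n2)c1)Nc1ccc(Cl)c(Cl)c1`, and compound 2, `COc1cc(-c2nn(-c3cccc(NC(=O)Nc4ccc(Cl)c(C(F)(F)F)c4)c3)cc2-c2ccncc2)ccc1Cl`, share a common core and differ in the aryl urea and in the oxygen substituent on the chlorophenyl ring. In a functional assay on NCI-H23 cells (Homo sapiens) for inhibition, read by sulforhodamine B assay, with a stated time of 48 h (on this read-out higher numbers stand for lower toxicity in this test and lower numbers for higher toxicity in this test), compound 1 reaches only the limit of the test, > 32500 nM. In this assay compound 2 likewise returns only a limit, > 32500 nM. Compound 2 therefore stands at the edge of what this assay can resolve, a situation summarised by the limit of > 32500 nM in this assay, at which 2 of the 2 values shown sit. Compound 3, `O=C(Nc1cccc(-n2cc(-c3ccncc3)c(-c3ccc(Cl)c(O)c3)n2)c1)Nc1ccc(Cl)c(C(F)(F)F)c1`, has not yet been measured; it differs from compound 2 by hydrogen in place of methyl on an oxygen on an aromatic ring. Since both compounds that flank it sit at the limit, the step expected from compound 2 to compound 3 in this assay is a step that the limit leaves unreadable from compound 2 to compound 3, which is to say none beyond the scatter. For compound 3 the estimated value in this assay is 40000 nM, with a range from 15000 nM to 100000 nM.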

Compound 3, concentration lethal to 50% of the cells: 26100 nM
The estimate for compound 3 lay 1.5-fold (0.19 log units) above the measured number; the measured number falls inside the stated range.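

In this assay the change from methoxy to hydroxy can now be given a size, though only as a floor, with the step reading an at least 1.2-fold lower number from compound 2 to compound 3 (0.09 log units; that floor lies within the scatter). The change to trifluoromethyl in place of chloro on an aromatic carbon, with the hydroxy kept, can be read only in the same way, as an at least 1.2-fold lower number from compound 1 to compound 3 (0.09 log units; that floor lies within the scatter). Going by these compounds, neither floor shows a change beyond the scatter, and the true size of both steps stays unknown, as each starts from a limit: the limit of > 32500 nM in this assay, at which 2 of the 3 values shown sit.

The compounds shown leave open how an amine or a carboxylic acid in place of the hydroxy would read in this assay. They also leave open whether a longer chain on that oxygen, such as ethoxy, would give a number or another limit.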